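A few compounds are considered here, and "the series" means these few. Any claim that something is new, unique, unknown or untested is made for them only; others in the source may bear on it.

Measured compounds:
- Compound 1 `Cn1ccc2cc(-c3cc4nccc(-c5ccc(F)cc5)n4n3)ccc21`: 5210 nM
- Compound 2 `COc1cc(-c2ccnc3cc(-c4ccc5c(ccn5C)c4)nn23)cc(OC)c1OC`: 19 nM

In a functional assay on HeLa cells (Homo sapiens) for inhibition, read by CCK-8 assay, with a stated time of 48 h (a higher number here means a weaker inhibitor, a lower number a stronger inhibitor), compound 2 gives 19 nM, the lower of the two numbers, while compound 1 gives 5210 nM. The gap between them lies beyond the scatter.

Compound 3 `COc1cc(-c2ccnc3cc(-c4ccc(C(C)=O)cc4)nn23)cc(OC)c1OC` has not yet been measured. It differs from compound 2 in one place: 4-acetylphenyl in place of 1-methyl-1H-indol-5-yl on an aromatic carbon. Here, 4-acetylphenyl stands in place of 1-methyl-1H-indol-5-yl on an aromatic carbon of the five-membered aromatic ring with 2 nitrogen. For the measured compounds named here, no measured pair shows this exchange, so the size of the step remains a judgement. A move to a higher number in this assay, beyond the scatter, is expected, since compound 2 at 19 nM already sits low. The expected change is a 16-fold higher number from compound 2 to compound 3 (1.20 log units; beyond the scatter). For compound 3 the estimated value is 300 nM, with an expected range of 60 nM to 1800 nM.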

Compound 3, half-maximal inhibitory concentration: 1810 nM
Beside the measured number, compound 3's estimate is 6.0-fold (0.78 log units) below it, outside the stated range (above it).
By their numbers in this assay, from the lowest: compound 2; then compound 3; then compound 1.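

In this assay, placing 4-acetylphenyl in place of 1-methyl-1H-indol-5-yl on an aromatic carbon gives a 95-fold higher number from compound 2 to compound 3 (1.98 log units; beyond the scatter) and this is the first change in a single place among these compounds. It shows that this position of the five-membered aromatic ring with 2 nitrogen is not indifferent to its aryl group: with the rest of the molecule held the same, this one exchange alone produces a large step beyond the scatter. Nothing measured here accounts for the size of that step.

From the compounds shown here alone, whether the step comes from losing the 1-methyl-1H-indol-5-yl group or from gaining the acetyl remains open, and a plain phenyl or a 4-aminophenyl at this place could separate the two. Going by these compounds, it is also open whether the same exchange would carry the same weight on the core of compound 1.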